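Cytotoxicity notes on compounds 1 to 3

The compounds below may be only part of what the source reports. "The series", "measured", "known", "first", "only" and "open" are said of these compounds alone.

Compound 1 `COc1ccc(C2CC(c3cc4ccccc4o3)=NN2C(=O)c2ccncc2)cc1` and compound 2 `CCn1cc(C(=O)N2N=C(c3cc4ccccc4o3)CC2c2ccc(N(C)C)cc2)c(=O)c2ccc(C)nc21` share the 1-benzofuran-2-yl group on the common core and differ in the acyl part and in the group on the saturated ring carbon. In an ADME assay on Vero cells (Chlorocebus sabaeus) for cytotoxicity, read by MTT assay, with a stated time of 72 h (on this read-out higher numbers stand for weaker inhibition and lower numbers for stronger inhibition), compound 1 gives only a limit of the assay, > 200000 nM. In this assay compound 2 likewise gives only a limit, > 206000 nM. Among the measured compounds shown here, compound 2 thus stands at the limit, as does compound 1; neither value is a number, so no step between the two can be read from these data, and no measured step of any kind exists so far.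

Compound 3 `CCn1cc(C(=O)N2N=C(c3cc4ccccc4o3)CC2/C=C/c2ccccc2)c(=O)c2ccc(C)nc21` is the next member to be measured. (2-phenylethenyl in place of 4-(dimethylamino)phenyl on a saturated ring carbon). Since both measured compounds sit at the limit, the expectation is that this assay will again not resolve a number. Compound 3 is expected to return a limit once more. The step that this estimate means, an at least 1.0-fold lower number from compound 2 to compound 3 (0.01 log units; that floor lies within the scatter), is expected to be none beyond the scatter. For compound 3 the estimate is 200000 nM, with a range from 100000 nM to 400000 nM.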

Compound 3, half-maximal inhibitory concentration: > 168000 nM
Compound 3 ended at the assay's limit; the forecaster's own chance of this, stated with the estimate: 80%; the middle value is on the limit's open side.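

In this assay compound 3 gives only a limit, > 168000 nM. Among the compounds shown here, compound 2 is also held at a limit, so no step between compound 2 and compound 3 can be read. The compounds shown leave open what number any of them would give in this assay, and whether 2-phenylethenyl in place of 4-(dimethylamino)phenyl changes the read-out at all.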